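A Triazole Substituent Swap at the Assay Ceiling

This account rests on a few compounds, and the source may have more. Where it says the series, first, only, none or still open, it means among the compounds named here.

Compound 1 `CC(C)n1ncc2c(C(=O)NCc3ccccc3)cccc21` gives only the limit > 40000 nM in a functional assay on MCF7 cells (Homo sapiens) for inhibition, read by MTT assay, with a stated time of 72 h (on this read-out higher numbers stand for weaker inhibition and lower numbers for stronger inhibition), and no number. Compound 2 `Cc1ccc(-n2cc(CNC(=O)c3cccc4c3cnn4C(C)C)nn2)cc1` likewise reaches only the limit > 40000 nM in this assay, so where it stands on the numbers shown is simply unresolved, because of the limit of > 40000 nM in this assay, at which 2 of the 2 values shown sit. Compound 3 `COc1ccc(Cn2cc(CNC(=O)c3cccc4c3cnn4C(C)C)nn2)cc1` differs from compound 2 in one place: 4-methoxybenzyl in place of 4-methylphenyl on an aromatic nitrogen. No step between two measured compounds is shown, so no direction of change can be read from the data. Compound 3 is expected to give 40000 nM, within 10000 nM to 100000 nM, and the step of a number no higher from compound 2 to compound 3 (the limit leaves the size open) is expected to stay within the scatter.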

Compound 3, half-maximal inhibitory concentration: > 40000 nM
Compound 3: only a limit was reported (the forecaster's own chance of this, stated with the estimate: 80%); the middle value lies on the limit itself.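

No step can be read from compound 2 to compound 3 in this assay, because both results are limits and not numbers: the limit of > 40000 nM in this assay, at which 3 of the 3 values shown sit. The compounds shown leave open what inhibition any of them actually gives, and whether 4-methoxybenzyl and 4-methylphenyl differ at all.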